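A few compounds are considered here, and "the series" means these few. Any claim that something is new, unique, unknown or untested is made for them only; others in the source may bear on it.

Measured in a functional assay on A549 cells (Homo sapiens) for cytotoxicity, read by MTT assay, with a stated time of 48 h; a higher number here means a weaker inhibitor, a lower number a stronger inhibitor:
- Compound 1 `C=C1C(=O)O[C@H]2CC3=C[C@H](C/C(C)=C/[C@@H](OC(=O)c4ccc([N+](=O)[O-])cc4)[C@H]12)OC3=O`: > 10000 nM (a limit)
- Compound 2 `C=C1C(=O)O[C@H]2CC3=C[C@H](C/C(C)=C/[C@@H](OC(=O)/C=C/c4ccc(N(C)C)cc4)[C@H]12)OC3=O`: > 10000 nM (a limit)
- Compound 3 `C=C1C(=O)O[C@H]2CC3=C[C@H](C/C(C)=C/[C@@H](OC(=O)/C=C/c4ccc(C(F)(F)F)cc4)[C@H]12)OC3=O`: 5900 nM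

Compound 1 gives only a limit, > 10000 nM. This is the limit of > 10000 nM in this assay, at which 2 of the 3 values shown sit.

Compound 4 `C=C1C(=O)O[C@H]2CC3=C[C@H](C/C(C)=C/[C@@H](OC(=O)CCCCBr)[C@H]12)OC3=O` differs from compound 1 on a carbonyl carbon: 4-bromobutyl in place of 4-nitrophenyl on a carbonyl carbon.

Among the measured compounds shown here, two measured steps bear on this change. The first, a step that the two limits leave unreadable from compound 1 to compound 2, replaces the group at that same place, but its size cannot be read. The second, an at least 1.6-fold lower number from compound 2 to compound 3 (0.22 log units; that floor lies within the scatter), is a change on an aromatic carbon. Neither step involves an open chain such as 4-bromobutyl.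

Compound 3 gives 5900 nM, so a measurable number is possible with this shared core. The expected change is small and towards a lower number, an at least 1.2-fold lower number from compound 1 to compound 4 (0.09 log units; that floor lies within the scatter). For compound 4, the estimate is 8000 nM, with an expected range of 3000 nM to 20000 nM.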

Compound 4, half-maximal inhibitory concentration: > 10000 nM
Compound 4: only a limit was reported; the forecaster's own chance of this, stated with the estimate: 45%; at least 1.2-fold (0.09 log units) between middle value and limit.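

The steps from compound 1 and from compound 2 to compound 4 cannot be read, since all three compounds give only a limit: the limit of > 10000 nM in this assay, at which 3 of the 4 values shown sit. Going by these compounds, whether 4-bromobutyl in place of 4-nitrophenyl changes the result in this assay remains open.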